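The source may hold more compounds than are shown below. What is called first, only, known or untested is meant among the compounds shown, and "the series" means these compounds.

Compound 2 `CC1(C)c2[nH]nc(NC(=O)c3ccc(Br)cc3)c2CN1Cc1cccc(F)c1F` gives 950 nM in an assay on Sf21 cells for inhibition of high affinity nerve growth factor receptor (Homo sapiens), read by HTRF, with a stated time of 30 min, in the presence of a further agent that is not named here (on this read-out lower numbers stand for stronger inhibition and higher numbers for weaker inhibition), the highest of the three numbers recorded. Compound 3 `CC1(C)c2[nH]nc(NC(=O)c3ccc(Br)cc3)c2CN1Cc1cc(F)cc(F)c1` stands nearest, with 710 nM, and the step of a 1.3-fold lower number from compound 2 to compound 3 (0.13 log units; within the scatter) stays within the scatter. Compound 1 `CC1(C)c2[nH]nc(NC(=O)c3ccc(F)cc3)c2CN1Cc1cccc(F)c1F` stands furthest, at 210 nM, and the step of a 4.5-fold higher number from compound 1 to compound 2 (0.66 log units; beyond the scatter) lies beyond it. Compound 4 `CN1CCN(c2ccc(C(=O)Nc3n[nH]c4c3CN(Cc3cccc(F)c3F)C4(C)C)cc2)CC1` differs from compound 2 by 4-methylpiperazin-1-yl in place of bromo on an aromatic carbon. For the measured compounds named here, only the step of a 4.5-fold higher number from compound 1 to compound 2 (0.66 log units; beyond the scatter) bears on this position; it shows that a change there can shift this assay by a modest amount, but no measured step involves the entering group, so the direction is open. Compound 4 is therefore expected to show a 2.4-fold lower number from compound 2 to compound 4 (0.38 log units; beyond the scatter) in this assay, with wide uncertainty. Compound 4 is estimated at 400 nM, between 80 nM and 2000 nM.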

Compound 4, half-maximal inhibitory concentration: 17 nM
Compound 4: middle estimate off by 24-fold (1.37 log units), on the high side; the whole stated range lies above it.
By their numbers in this assay, from the lowest: compound 4; then compound 1; then compounds 3 and 2 (each within the scatter of the next).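

The earlier swap between two halogens moved the number in this assay only modestly. With 4-methylpiperazin-1-yl on this aromatic carbon, the change is far larger, with a 56-fold lower number from compound 2 to compound 4 (1.75 log units; beyond the scatter) and a 12-fold lower number from compound 1 to compound 4 (1.09 log units; beyond the scatter), so this position accepts a much bigger group, carrying a six-membered non-aromatic ring, and the number falls well below those of both halogen compounds. No evidence at hand accounts for the size of these steps. On these data alone, whether the gain rests on the ring, its nitrogens or the methyl group stays open; a morpholine, a piperidine or an unsubstituted piperazine at this place would separate them.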